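Cyclopropyl to cyclohexyl: a small expected shift

This account rests on a few compounds, and the source may have more. Where it says the series, first, only, none or still open, it means among the compounds named here.

Measured in a functional assay on A549 cells (Homo sapiens) for cytotoxicity, read by sulforhodamine B assay, with a stated time of 72 h; a higher number here means a weaker inhibitor, a lower number a stronger inhibitor:
Compound 1 `CC(C)(C)NC(=S)c1c(N)sc(-c2ccc(Cl)cc2)c1-c1ccc(Cl)cc1`: > 50000 nM
Compound 2 `Clc1ccc(-c2sc3ncnc(NC4CC4)c3c2-c2ccc(Cl)cc2)cc1`: 42800 nM

Compound 1 gives only a limit of the assay and not a number: the limit of > 50000 nM in this assay, at which 1 of the 2 values shown sits. Among the measured compounds shown here, compound 2 therefore holds the only true number so far, 42800 nM, and a high number here marks a weak inhibitor.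

Compound 3 `Clc1ccc(-c2sc3ncnc(NC4CCCCC4)c3c2-c2ccc(Cl)cc2)cc1` keeps the shared core of compound 2 and alters one group, with cyclohexyl in place of cyclopropyl on a nitrogen on an aromatic ring. For the measured compounds named here, no measured pair shows what such a swap does in this assay, so no step beyond the scatter is expected, with only a slight lean towards a lower number. The estimated change is a 1.4-fold lower number from compound 2 to compound 3 (0.15 log units; within the scatter). For compound 3 the expected value is 30000 nM, with an estimated range of 12000 nM to 50000 nM.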

Compound 3, half-maximal inhibitory concentration: > 50000 nM
Compound 3 gave a limit, no number; the forecaster's own chance of this, stated with the estimate: 35%; at least 1.6-fold (0.22 log units) between middle value and limit.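

In this assay compound 3 gives > 50000 nM, which is a limit of the assay and not a number. Among the compounds shown here, this is the first step read at this position, with cyclohexyl in place of cyclopropyl on the nitrogen: an at least 1.1-fold higher number from compound 2 to compound 3 (0.06 log units; that floor lies within the scatter). The larger carbon ring shows no sign of a lower number, though the true size of the step cannot be read, and most of the values now sit at the top of the assay's range: the limit of > 50000 nM in this assay, at which 2 of the 3 values shown sit.

The compounds shown leave open whether any group on this nitrogen can bring the number clearly down, for example a piperazine, a morpholine or an open butyl chain. They also leave open how the two chlorophenyl groups on the shared core bear on the result.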